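The source may report more compounds than this note shows. Statements on the series, on what has been measured and on what is new or still open speak of the compounds shown alone.

Measured in a functional assay on KB cells (Homo sapiens) for antiproliferative activity, read by sulforhodamine B assay, with a stated time of 3 days; on this read-out higher numbers stand for weaker inhibition of growth and lower numbers for stronger inhibition of growth:
Compound 1 `O=C(Nc1cccc(Nc2ncc(F)c(Nc3ccc(F)cc3)n2)c1)c1cccc([N+](=O)[O-])c1` gives 15100 nM.
Compound 2 `O=C(Nc1cccc(Nc2ncc(F)c(Nc3ccc(F)cc3)n2)c1)c1ccccc1` gives > 10000 nM, which is a limit and not a number.
Compound 3 `O=C(Nc1cc(Cl)cc(Cl)c1)c1cccc(Nc2ncc(F)c(Nc3ccc(F)cc3)n2)c1` gives 20100 nM.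

Compound 1 at 15100 nM and compound 3 at 20100 nM lie within the scatter of each other. Compound 4 `CN(C)CC(=O)Nc1cccc(Nc2ncc(F)c(Nc3ccc(F)cc3)n2)c1` differs from compound 3 as follows: (((dimethylamino)methyl)carbonyl)amino in place of (3,5-dichlorophenyl)carbamoyl on an aromatic carbon. Among the compounds with values here, two measured steps bear on this change, a step that the limit leaves unreadable from compound 1 to compound 2 and a step that the limit leaves unreadable from compound 2 to compound 3, and neither has a readable size. With only compound 3 at 20100 nM and compound 1 at 15100 nM as readable anchors, no change beyond the scatter is expected in this assay, in either direction. The expected step is a 1.7-fold lower number from compound 3 to compound 4 (0.22 log units; within the scatter). For compound 4 the estimated value is 12000 nM, with an expected range from 3000 nM to 30000 nM.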

Compound 4, concentration for 50% growth inhibition: 1260 nM
Estimate against measurement, compound 4: 9.5-fold (0.98 log units) above; the measured number lies below the stated range.
By their numbers in this assay, from the lowest: compound 4; then compounds 1 and 3 (each within the scatter of the next).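

In this assay, the group on this aromatic carbon proves able to shift the number well beyond the scatter: (((dimethylamino)methyl)carbonyl)amino in place of (3,5-dichlorophenyl)carbamoyl gives a 16-fold lower number from compound 3 to compound 4 (1.20 log units; beyond the scatter), and (dimethylamino)methyl in place of 3-nitrophenyl on a carbonyl carbon gives a 12-fold lower number from compound 1 to compound 4 (1.08 log units; beyond the scatter). In place of phenyl, the same group gives an at least 7.9-fold lower number from compound 2 to compound 4 (0.89 log units; beyond the scatter). Compound 2 carries a limit and not a number: the limit of > 10000 nM in this assay, at which 1 of the 4 values shown sits.

Going by these compounds, whether the gain comes from the dimethylamino group or from the loss of the aromatic ring stays open. On these data alone, how a primary amine, a pyrrolidine or a longer chain would read here also stays open.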